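The source may report more compounds than this note shows. Statements on the series, on what has been measured and on what is new or still open speak of the compounds shown alone.

In a functional assay on the whole organism (strain albino) for inhibition, with Rattus norvegicus as the target, read by paw edema, with stated times of 30 min and 5 h, at a dose of 100 mg/kg by the oral route (on this read-out lower numbers stand for less inhibition and higher numbers for more inhibition at the one dose given (going by the name of the read-out)), compound 1 `Nc1ccc(C(=O)/C=C/c2ccco2)cc1` gives 30%, the lowest of the three numbers in hand. Among the measured compounds shown here, compound 2 `O=C(CO[N+](=O)[O-])Nc1ccc(C(=O)/C=C/c2ccc(Cl)cc2)cc1` gives 60% and compound 3 `COc1ccc(/C=C/C(=O)c2ccc(NC(=O)CO[N+](=O)[O-])cc2)cc1` gives 46%; the one measured step, a number 14 percentage points lower from compound 2 to compound 3 (beyond the scatter), concerns a substituent on the other aromatic ring and does not bear on the change at hand. Compound 4 `CC(Br)C(=O)Nc1ccc(C(=O)/C=C/c2ccco2)cc1` differs from compound 1 by (1-bromoethyl)carbonyl in place of hydrogen on a nitrogen on an aromatic ring. For the measured compounds named here, no measured pair shows that change alone, yet compound 2 and compound 3 both carry a carbonyl substituent on this nitrogen and stand higher than compound 1. A modest rise is therefore expected, a number 15 percentage points higher from compound 1 to compound 4 (beyond the scatter). Compound 4 is estimated at 45%, within a range of 30% to 62%.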

Compound 4, a percentage reported as inhibition, in the whole organism at one dose (the size of the read-out at that dose, not a potency): 34%
Compound 4: middle estimate off by 11 percentage points, on the high side; the range from low to high includes it.
By their numbers in this assay, from the lowest: compounds 1 and 4 (each within the scatter of the next); then compound 3; then compound 2.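

In this assay, among the compounds shown here, (1-bromoethyl)carbonyl in place of hydrogen on this nitrogen gives a number 4 percentage points higher from compound 1 to compound 4 (within the scatter), the only step measured at this position. On the core of compound 1, this change therefore cannot be told apart from the amino group. No measured evidence bears on this result.

As far as these compounds go, whether the carbonyl substituent carried on this nitrogen by compound 2 and compound 3 would shift the number on the core of compound 1 remains open. So does the outcome for a longer acyl chain or a carboxylic acid there.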